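Three inactive analogues and a pyridine acid awaiting its number

The compounds below may be only part of what the source reports. "The series", "measured", "known", "first", "only" and "open" are said of these compounds alone.

The series is read in an assay on isolated protein for activation of cGMP-dependent protein kinase 1 (Homo sapiens), read by ADP-Glo, with stated times of 30 min and 2 h; a lower number here means that less compound is needed, a higher number that more compound is needed for the effect. Compound 1 `COc1cccc([C@@H](CO)O[C@H]2CCCN(Cc3ccc(C(=O)O)cc3C)[C@H]2c2ccccc2)c1` reaches only a limit of the assay, > 200000 nM, and no number. Compound 2 `Cc1cc(C(=O)O)ccc1CN1CC[C@H](OC(CO)c2cc(Cl)cc(Cl)c2)[C@@H]1c1ccccc1` gives a number, 185000 nM. Compound 3 `OC[C@@H](O[C@H]1CCCN(Cc2ncc[nH]2)[C@H]1c1ccccc1)c1cc(Cl)cc(Cl)c1` likewise ends at a limit of the assay, > 200000 nM. Going by the values given here, compound 3 therefore stands where compound 1 stands, at the limit of > 200000 nM in this assay, at which 2 of the 3 values shown sit, while the single number in the set, that of compound 2, lies close by. Among the compounds with values here, no pair of these three differs in only one place, so no step between measured compounds can be counted.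

Compound 4 `Cc1nc(C(=O)O)ccc1CN1CCC[C@H](O[C@H](CO)c2cc(Cl)cc(Cl)c2)[C@@H]1c1ccccc1` differs from compound 3 by a group of 10 heavy atoms (7 carbon, 1 nitrogen, 2 oxygen; one six-membered aromatic ring with 1 hetero atom) in place of a group of 5 heavy atoms (3 carbon, 2 nitrogen; one five-membered aromatic ring with 2 hetero atoms), on a saturated chain carbon bound to an amine nitrogen in a ring. The closest measured relative of this change is compound 2, whose carboxylic-acid-bearing group on the same position gave 185000 nM, so nothing in the set points to a step beyond the scatter. Compound 4 is expected to sit at 200000 nM, within 90000 nM to 400000 nM, which means an expected step of a number no higher from compound 3 to compound 4 (the limit leaves the size open).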

Compound 4, half-maximal effective concentration: 144000 nM
Compound 4: middle estimate off by 1.4-fold (0.14 log units), on the high side; measured number inside the range.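

In this assay, placing the group of 10 heavy atoms, with its six-membered aromatic ring, in the stead of 1H-imidazol-2-yl, on a saturated chain carbon bound to an amine nitrogen in a ring, gives an at least 1.3-fold lower number from compound 3 to compound 4 (0.14 log units; that floor lies within the scatter). Going by these compounds alone, this is the first step that can be counted in the set, and it has only a floor and no fixed size, as compound 3 holds a limit and not a number: the limit of > 200000 nM in this assay, at which 2 of the 4 values shown sit. The change thus yields a measured number at this position, but that floor does not establish a real gain.

The whole group changes at once, so the compounds shown do not separate the part played by the carboxylic acid from that of the ring nitrogen or the methyl. As far as these compounds go, whether an amide or a primary amine in place of the carboxylic acid would give a lower number also stays open.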